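This account rests on a few compounds, and the source may have more. Where it says the series, first, only, none or still open, it means among the compounds named here.

Of the compounds shown here, three have been measured in a functional assay on cells (Endothelial cell, Bos taurus) for antiproliferative activity; on this read-out higher numbers stand for weaker inhibition and lower numbers for stronger inhibition. Compound 1 `COc1ccc(/C=C(/F)c2cc(OC)c(OC)c(OC)c2)cc1O` gives 1700 nM, compound 3 `COc1cc(/C=C/c2cc(O)c3ccsc3c2)cc(OC)c1OC` gives 38000 nM, and compound 2 `COc1ccc(/C(F)=C/c2cc(OC)c(OC)c(OC)c2)cc1F` gives 610000 nM. The number for compound 2 is the highest of the three and lies beyond the usual scatter from both others, which makes it the weakest inhibitor of this small set.

The next compound, compound 4 `COc1ccc(/C(F)=C/c2cc(OC)c(OC)c(OC)c2)cc1[N+](=O)[O-]`, differs from compound 2 in one place: nitro in place of fluoro on an aromatic carbon. This is nitro in place of fluoro on an aromatic carbon, ortho to a methoxy group. Within the data shown here, no measured pair shows this swap, so the data give no direct guide to its size. The expectation rests on where compound 2, at 610000 nM, stands: at the top of the numbers seen so far, with compound 3, at 38000 nM, the closest to it. A moderate move toward stronger inhibition, just beyond the scatter, therefore seems more likely than a move upward. The expected change is a 4.1-fold lower number from compound 2 to compound 4 (0.61 log units; beyond the scatter). For compound 4 the estimate is 150000 nM, with an expected range from 20000 nM to 900000 nM.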

Compound 4, half-maximal inhibitory concentration: > 3000000 nM
Compound 4 was reported as a limit (the forecaster's own chance of this, stated with the estimate: 15%); middle value at least 20-fold (1.30 log units) from the limit.
By their numbers in this assay, from the lowest: compound 1; then compound 3; then compound 2. At a limit, above all of these: compound 4.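

In this assay compound 4 is reported only as a limit, not as an exact number: the limit of > 3000000 nM in this assay, at which 1 of the 4 values shown sits.

Among these compounds, replacing fluoro with nitro on this aromatic carbon, ortho to a methoxy group, gives an at least 4.9-fold higher number from compound 2 to compound 4 (0.69 log units; beyond the scatter), the first direct reading of a change at this position. Among the compounds shown here, compound 2 already had the highest number among the earlier compounds, yet this swap shows that inhibition can become weaker still, so the position is sensitive to the group it carries.

From the compounds shown here alone, how far the true number for compound 4 lies past its limit stays unknown, so the step gives only a minimum size. With just fluoro and nitro shown at this carbon, it also remains open whether an amine, a hydroxyl or a chlorine atom there would give a lower number than compound 2.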